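Notes on the step from compound 3 to compound 4

A few compounds are considered here, and "the series" means these few. Any claim that something is new, unique, unknown or untested is made for them only; others in the source may bear on it.

Measured in a functional assay on NCI-H1975 cells (Homo sapiens) for cytotoxicity, read by MTT assay, with a stated time of 72 h; a higher number here means a weaker inhibitor, a lower number a stronger inhibitor:
- compound 1 `Cc1cc(C)cc(-n2c(Nc3ccccc3)nc3cnc(Nc4ccc(N5CCN(C)CC5)cc4)nc32)c1` gives 1910 nM
- compound 2 `OCCNc1ccc(Nc2ncc3nc(Nc4ccccc4)n(C4CCCC4)c3n2)cc1` gives 2810 nM
- compound 3 `C#Cc1cccc(Nc2nc3cnc(Nc4ccc(N5CCN(C)CC5)cc4)nc3n2C2CCCC2)c1` gives 650 nM

Compound 3 has the lowest number of the three, and compound 1 and compound 2 both lie beyond the scatter from it. Compound 4 `CN1CCN(c2ccc(Nc3ncc4nc(Nc5cc(Cl)ccc5Cl)n(C5CCCC5)c4n3)cc2)CC1` carries 2,5-dichlorophenyl in place of 3-ethynylphenyl on a nitrogen on an aromatic ring. Within the data shown here, no measured pair isolates this change. Since compound 3 at 650 nM is the lowest so far, a small move toward a higher number is expected, not clearly beyond the scatter. The estimated change is a 1.5-fold higher number from compound 3 to compound 4 (0.19 log units; within the scatter). For compound 4 the estimate is 1000 nM, with an expected range from 300 nM to 3000 nM.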

Compound 4, half-maximal inhibitory concentration: 2540 nM
Estimate against measurement, compound 4: 2.5-fold (0.40 log units) below; low and high end bracket the measured number.
By their numbers in this assay, from the lowest: compound 3; then compounds 1, 4 and 2 (each within the scatter of the next).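

In this assay, among these compounds, the exchange of 3-ethynylphenyl for 2,5-dichlorophenyl on the nitrogen gives a 3.9-fold higher number from compound 3 to compound 4 (0.59 log units; beyond the scatter) and is the first step that isolates a single place. The number at this position therefore depends on the aryl substituents, even though both groups count the same heavy atoms and neither carries a hydrogen-bond donor or acceptor. No measurement on hand accounts for the step.

On these data alone, whether one chlorine alone gives the same step remains open, as does the effect of a nitrile or an amine on this ring.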